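A few compounds are considered here, and "the series" means these few. Any claim that something is new, unique, unknown or untested is made for them only; others in the source may bear on it.

Working notes on the series. One shared core carries all four compounds: compound 1 `CC(=O)Oc1ccc(/C=C/S(=O)(=O)CCc2ccc(NC(=O)c3ccccc3)cc2)cc1OC(C)=O`, compound 2 `CC(=O)Oc1ccc(/C=C/S(=O)(=O)CCc2ccc(NC(=O)c3ccc(F)cc3)cc2)cc1OC(C)=O`, compound 3 `CC(=O)Oc1ccc(/C=C/S(=O)(=O)CCc2ccc(NC(=O)c3cc(F)cc(F)c3)cc2)cc1OC(C)=O` and the not yet measured compound 4 `CC(=O)Oc1ccc(/C=C/S(=O)(=O)CCc2ccc(NC(=O)c3ccc([N+](=O)[O-])cc3)cc2)cc1OC(C)=O`. In an ADME assay on TZM cells (Homo sapiens) for cytotoxicity, read by CCK-8 assay, with a stated time of 2 days (a lower number here means that less compound is tolerated, a higher number that more compound is tolerated), compound 1 gives 108000 nM, compound 2 gives 162000 nM, and compound 3 gives 225000 nM. On these numbers compound 2 stands within the scatter of both other compounds: the step of a 1.5-fold higher number from compound 1 to compound 2 (0.18 log units; within the scatter) is within the scatter, as is the step of a 1.4-fold higher number from compound 2 to compound 3 (0.14 log units; within the scatter), and only the longer step of a 2.1-fold higher number from compound 1 to compound 3 (0.32 log units; beyond the scatter) reaches beyond it, and then only modestly, in this assay.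

The change to compound 4 is nitro in place of fluoro on an aromatic carbon. For the measured compounds named here, no measured step swaps these two groups; the measured steps concern fluoro in place of hydrogen or a second fluoro on the same ring, and two of the three stayed within the scatter. The whole spread of the measured numbers in this assay is narrow, so the expectation for compound 4 is no step beyond the scatter in either direction, which means an estimated step of a 1.1-fold lower number from compound 2 to compound 4 (0.03 log units; within the scatter). For compound 4 the estimate in this assay is therefore 150000 nM, with an expected range from 75000 nM to 300000 nM.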

Compound 4, half-maximal cytotoxic concentration: 160000 nM
Compound 4: middle estimate off by 1.1-fold (0.03 log units), on the low side; the range from low to high includes it.
By their numbers in this assay, from the lowest: compounds 1, 4, 2 and 3 (each within the scatter of the next, the first and the last beyond it).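

At this position, on an aromatic carbon para to a large group, this assay does not separate nitro from fluoro: the exchange of one fluorine for the three heavy atoms of nitro, with its 2 hydrogen-bond acceptors, gives a 1.0-fold lower number from compound 2 to compound 4 (0.01 log units; within the scatter). Nitro in place of hydrogen gives a 1.5-fold higher number from compound 1 to compound 4 (0.17 log units; within the scatter), and 4-nitrophenyl in place of 3,5-difluorophenyl gives a 1.4-fold lower number from compound 3 to compound 4 (0.15 log units; within the scatter), so compound 4 lies within the scatter of all three other compounds and adds a non-fluorine group to a series whose only step beyond the scatter remains the one between compound 1 and compound 3. No measurement is at hand that bears on the origin of these numbers.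

The compounds shown leave open whether an amine, a carboxylic acid or a longer chain on the same aromatic carbon would give a step beyond the scatter in this assay. They also leave open whether a change elsewhere on the shared core, such as free hydroxyl groups in place of the two acetyloxy groups, would move the numbers further than any exchange on this ring has so far.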